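A few compounds are considered here, and "the series" means these few. Any claim that something is new, unique, unknown or untested is made for them only; others in the source may bear on it.

In an ADME assay on MT2 cells (Homo sapiens) for cytotoxicity, read by XTT assay, with a stated time of 4 days (on this read-out lower numbers stand for higher toxicity in this test and higher numbers for lower toxicity in this test), two compounds sharing one core have been measured so far. Compound 1 (`Cc1nc(C(NC(=O)C(=O)Nc2ccc(Cl)cc2)C2CCCNC2)sc1CO`) gives > 81000 nM, which is a limit of the assay and not a number. Compound 2 (`CC(=O)N1CCCCC1C(NC(=O)C(=O)Nc1ccc(Cl)cc1)c1nc(C)c(CCO)s1`) gives > 84000 nM, which is likewise a limit. Among the compounds with values here, compound 2 therefore has no numerical value in this assay, and the only other measured compound stands at a limit too.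

The next compound is compound 3 (`Cc1nc(C(NC(=O)C(=O)Nc2ccc(Cl)cc2)C2CCCNC2)sc1CCO`). It differs from compound 2 in one place, with piperidin-3-yl in place of 1-acetylpiperidin-2-yl on a saturated chain carbon bound to an amide-type nitrogen and an aromatic carbon. Compound 1 carries piperidin-3-yl as well, and its reading of > 81000 nM is also a limit. This gives no reason to expect higher toxicity from that group in this assay. The expected change an at least 1.0-fold lower number from compound 2 to compound 3 (0.02 log units; that floor lies within the scatter) is therefore no step beyond the usual scatter, in either direction. Compound 3 is estimated at 80000 nM, with an expected range from 35000 nM to 150000 nM.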

Compound 3, half-maximal cytotoxic concentration: > 78500 nM
Compound 3: only a limit was reported (the forecaster's own chance of this, stated with the estimate: 70%); the middle value does not contradict the limit.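

In this assay compound 3 gives > 78500 nM, which is a limit of the assay and not a number. Within the data shown here, compound 1 and compound 2 also stand at limits, and no step from either of them to compound 3 can be read. The compounds shown leave open at what concentration any of the three becomes cytotoxic and whether either change alters that concentration.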